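A few compounds are considered here, and "the series" means these few. Any claim that something is new, unique, unknown or untested is made for them only; others in the source may bear on it.

Within the data shown here, compound 1 `Cc1oc(-c2ccccc2Cl)nc1CN1CCC(C(=O)NCCCN2C[C@H](C)C[C@H](C)C2)CC1` is the one member of this small set with a plain number in an ADME assay on microsomes from liver (Rattus norvegicus) for metabolic stability, read by LC-MS, using NADPH, at 37 degrees C; on this read-out higher numbers stand for a longer-lived compound and lower numbers for a shorter-lived compound: compound 1 gives 0.25 h. Compound 2 `Cc1ccccc1-c1nc(CN2CCC(C(=O)NCCCN3CCCCC3)CC2)c(C)o1` reaches only a limit of the assay in this assay, > 0.5 h. Compound 3 `Cc1ccccc1-c1nc(CN2CCC(C(=O)N3CCN(CCN(C)C)CC3)CC2)c(C)o1` likewise reaches only a limit, > 0.5 h. The step that the two limits leave unreadable from compound 2 to compound 3, 4-(2-(dimethylamino)ethyl)piperazin-1-yl in place of (3-(piperidin-1-yl)propyl)amino on a carbonyl carbon, cannot be sized because the limit of > 0.5 h in this assay, at which 2 of the 3 values shown sit, hides its end. Among the measured compounds shown here, compound 4 `CCc1ccccc1-c1nc(CN2CCC(C(=O)NCCCN3C[C@H](C)C[C@H](C)C3)CC2)c(C)o1` differs from compound 1 by ethyl in place of chloro on an aromatic carbon, a change that no measured step covers. Compound 4 is therefore expected to stay close to compound 1, a step of a 1.2-fold higher number from compound 1 to compound 4 (0.08 log units; within the scatter) that sits within the scatter. Compound 4 is estimated at 0.3 h, between 0.12 h and 0.7 h.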

Compound 4, half-life: 0.283 h
Beside the measured number, compound 4's estimate is 1.1-fold (0.03 log units) above it; the range from low to high includes it.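

Among these compounds, this is the first readable step at this place, on an aromatic carbon ortho to a large group: in this assay, ethyl in place of chloro gives a 1.1-fold higher number from compound 1 to compound 4 (0.05 log units; within the scatter) and so swaps one chlorine for two carbons with no difference the read-out can separate from scatter. Nothing measured here gives a reason for this result. As far as these compounds go, it remains open whether a methoxy, an amine or a carboxylic acid at this place would leave the half-life just as close to that of compound 1. The step from compound 2 to compound 3 still cannot be read: the limit of > 0.5 h in this assay, at which 2 of the 4 values shown sit.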